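From diethylamino to 3-methylpiperidin-1-yl: a step behind limits

A few compounds are considered here, and "the series" means these few. Any claim that something is new, unique, unknown or untested is made for them only; others in the source may bear on it.

In an ADME assay on MT4 cells (Homo sapiens) for cytotoxicity, read by MTT assay, with a stated time of 4 days (on this read-out lower numbers stand for higher toxicity in this test and higher numbers for lower toxicity in this test), compound 3 `CCN(CC)c1nc(Cc2c(F)cccc2F)c(C)c(=O)[nH]1` gives > 81000 nM as its reading, which is a limit and not a number. Compound 2 `Cc1c(Cc2c(F)cccc2F)nc(N(C)C)[nH]c1=O` gives > 89000 nM in this assay as its reading, also a limit. Compound 4 `Cc1c(Cc2c(F)cccc2F)nc(N2CCCC(C)C2)[nH]c1=O` is still unmeasured. It differs from compound 3 by having 3-methylpiperidin-1-yl in place of diethylamino on an aromatic carbon and so grows by a ring. Compound 1 `CC1CCCN(c2nc(Cc3c(F)cccc3F)cc(=O)[nH]2)C1` carries that same group and gives > 78000 nM in this assay as its reading, again a limit. Going by the values given here, the one measured step that bears on this is a step that the two limits leave unreadable from compound 2 to compound 3 with diethylamino in place of dimethylamino, so it offers no size to carry over. With all three readings being limits, no step beyond the usual scatter is expected in either direction. The estimated change is an at least 1.0-fold lower number from compound 3 to compound 4 (0.03 log units; that floor lies within the scatter) and a limit is again the likeliest report. For compound 4 the estimate is 75000 nM and the expected range runs from 45000 nM up to 95000 nM in this reading.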

Compound 4, half-maximal cytotoxic concentration: > 75000 nM
Compound 4: no number, only a limit (the forecaster's own chance of this, stated with the estimate: 90%); the middle value sits exactly at the limit.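

Compound 4, like compound 1, compound 2 and compound 3, is reported only as a limit, so the steps to compound 4 from compound 1, compound 2 and compound 3 cannot be read. The compounds shown leave open at what concentration any of them becomes toxic to these cells, and whether the changes between them matter at all.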